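The compounds below may be only part of what the source reports. "The series", "measured", "known", "first", "only" and "open" are said of these compounds alone.

Compound 1 `COc1ccc(C(=O)Oc2ccc(NC(=O)Nc3ccc(Cl)c(C(F)(F)F)c3)cc2)cc1`: 33800 nM
Compound 2 `O=C(Nc1ccccc1)Nc1ccc(OC(=O)c2ccc([N+](=O)[O-])cc2)cc1`: 185000 nM

Going by the values given here, in a functional assay on HT-29 cells (Homo sapiens) for antiproliferative activity, read by MTT assay, with a stated time of 48 h (on this read-out higher numbers stand for weaker inhibition and lower numbers for stronger inhibition), compound 2 gives 185000 nM, the higher of the two numbers measured so far; compound 1 gives 33800 nM, and the gap between the two lies beyond the usual scatter. Compound 3 `Cc1ccc(C(=O)Oc2ccc(NC(=O)Nc3ccccc3)cc2)cc1` differs from compound 2 in a single place: methyl in place of nitro on an aromatic carbon. Among the compounds with values here, no pair of measured compounds shows this change, so its direction is open. A step of modest size, or none beyond the scatter, is expected, a 1.5-fold lower number from compound 2 to compound 3 (0.19 log units; within the scatter). Compound 3 is estimated at 120000 nM, within a range from 30000 nM to 400000 nM.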

Compound 3, half-maximal inhibitory concentration: 19900 nM
Beside the measured number, compound 3's estimate is 6.0-fold (0.78 log units) above it; the whole stated range lies above it.
By their numbers in this assay, from the lowest: compounds 3 and 1 (each within the scatter of the next); then compound 2.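

Changing 4-nitrophenyl to 4-methylphenyl in this assay gives a 9.3-fold lower number from compound 2 to compound 3 (0.97 log units; beyond the scatter) and so settles the direction of this change for this pair: methyl gives the stronger inhibition. It also shows that the group on this aromatic carbon, para to a large group, can move the number beyond the scatter. Nothing measured here accounts for the step.
This single pair cannot show whether the same change would act alike on the core of compound 1. Going by these compounds, how an amine, a carboxylic acid or a longer chain would fare at this position remains open.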